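The source may report more compounds than this note shows. Statements on the series, on what has been measured and on what is new or still open speak of the compounds shown alone.

Measured compounds:
- compound 1, `COc1ccc(-c2csc(NC(=O)COc3ccc(C(=O)c4ccc(F)cc4)cc3C)n2)cc1`: 5400 nM
- compound 2, `COc1ccc(-c2csc(NC(=O)COc3ccc(C(=O)c4cccc(Br)c4)cc3C)n2)cc1`: 39200 nM

Among the measured compounds shown here, in a functional assay on Ehrlich cells (Mus musculus) for cytotoxicity, read by MTT assay, with a stated time of 48 h (a lower number here means a stronger inhibitor, a higher number a weaker inhibitor), compound 2 stands at the highest of the two numbers so far; its nearest neighbour is compound 1, and the step of a 7.3-fold higher number from compound 1 to compound 2 (0.86 log units; beyond the scatter) separates them, a modest but real shift with the change from 4-fluorophenyl to 3-bromophenyl on the carbonyl carbon.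

Compound 3, `COc1ccc(-c2csc(NC(=O)COc3ccc(C(=O)c4cccc(F)c4)cc3C)n2)cc1`, has not yet been measured in this assay. It differs from compound 2 in one place: fluoro in place of bromo on an aromatic carbon. For the measured compounds named here, only one measured step bears on this change, a 7.3-fold higher number from compound 1 to compound 2 (0.86 log units; beyond the scatter), and it mixes two alterations at once, the halogen and its position on the ring, so it cannot be cleanly split. Compound 3 keeps the position of compound 2 but carries the halogen of compound 1, so the expectation is a number below that of compound 2 and above that of compound 1, with the step of a 2.6-fold lower number from compound 2 to compound 3 (0.42 log units; beyond the scatter) estimated as the likely size. Compound 3 is therefore expected to give about 15000 nM in this assay, with a range from 5000 nM to 45000 nM.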

Compound 3, half-maximal inhibitory concentration: 30700 nM
Compound 3: middle estimate off by 2.0-fold (0.31 log units), on the low side; the measured number falls inside the stated range.
By their numbers in this assay, from the lowest: compound 1; then compounds 3 and 2 (each within the scatter of the next).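

In this assay, swapping the halogen at the 3-position of the phenyl ring gives a 1.3-fold lower number from compound 2 to compound 3 (0.11 log units; within the scatter), so compound 2 and compound 3 cannot be told apart, and bromo and fluoro read alike at this place on the ring. The other new comparison keeps the fluoro and changes only its place, and a 5.7-fold higher number from compound 1 to compound 3 (0.75 log units; beyond the scatter) ( 3-fluorophenyl in place of 4-fluorophenyl ) is a step beyond the scatter, which separates what the earlier step between compound 1 and compound 2 had mixed: among these three compounds, the number follows the place of the halogen rather than its identity, and compound 1 alone, with its 4-fluorophenyl, stands apart from the other two. No measurement shown offers a reason for this.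

From the compounds shown here alone, whether bromo also matches fluoro in the other place remains open, and a 4-bromophenyl on the same carbonyl would test that directly. Also open, going by these compounds, is whether a halogen is needed at all, a question that a plain phenyl, a 4-methoxyphenyl or a 4-aminophenyl on that carbonyl would address.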